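From 2-chlorophenyl to 3-bromophenyl on the shared core

A few compounds are considered here, and "the series" means these few. Any claim that something is new, unique, unknown or untested is made for them only; others in the source may bear on it.

- compound 1 `Cc1ccc(OCC(=O)NNC(=O)c2cc3ccccc3oc2=O)c(C(=O)c2ccccc2)c1`: 81100 nM
- compound 2 `Cc1ccc(OCC(=O)NNC(=O)c2cc3ccccc3oc2=O)c(C(=O)c2ccccc2Cl)c1`: 47600 nM

Both compounds were measured in a functional assay on Ehrlich cells (Mus musculus) for cytotoxicity, read by LDH release, with a stated time of 48 h; a lower number here means a stronger inhibitor, a higher number a weaker inhibitor. Going by the values given here, compound 2 stands level with compound 1, the only other compound with a number. Among the compounds with values here, the single measured step, a 1.7-fold lower number from compound 1 to compound 2 (0.23 log units; within the scatter), stays within the scatter, and it is chloro in place of hydrogen on an aromatic carbon.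

The next compound is compound 3 `Cc1ccc(OCC(=O)NNC(=O)c2cc3ccccc3oc2=O)c(C(=O)c2cccc(Br)c2)c1`, and the change is 3-bromophenyl in place of 2-chlorophenyl on a carbonyl carbon. Within the data shown here, no measured compound carries the 3-bromophenyl group, so the evidence is thin. Among the measured compounds shown here, only the step to compound 2 bears on this change, and only in part, since it too concerns the same phenyl group. That step gives no reason to expect a large move in this assay, and no direction can be drawn from it. The estimated step is a 1.1-fold higher number from compound 2 to compound 3 (0.02 log units; within the scatter), so nothing beyond the scatter is expected. For compound 3 the estimated value is 50000 nM, with an expected range from 22000 nM to 110000 nM.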

Compound 3, half-maximal inhibitory concentration: 68100 nM
The estimate for compound 3 lay 1.4-fold (0.13 log units) below the measured number; the range from low to high includes it.
By their numbers in this assay, from the lowest: compounds 2, 3 and 1 (each within the scatter of the next).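

In this assay, 3-bromophenyl in place of 2-chlorophenyl on a carbonyl carbon gives a 1.4-fold higher number from compound 2 to compound 3 (0.16 log units; within the scatter) and 3-bromophenyl in place of phenyl gives a 1.2-fold lower number from compound 1 to compound 3 (0.08 log units; within the scatter) in the same series. This place on the shared core now holds phenyl, 2-chlorophenyl and 3-bromophenyl, and all three steps among compound 1, compound 2 and compound 3 stay within the scatter, so the second halogenated group adds no separation that the first step had not shown, although compound 2 and compound 3 differ both in the halogen and in where it stands on the ring. Nothing measured here offers an explanation for how closely these numbers lie.

The compounds shown leave open whether the halogen and its place on the ring would each matter if taken alone, as the one step available joins the two. They also leave open whether a group of another kind on this phenyl ring, such as an amine or a carboxylic acid, would give a step beyond the scatter.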